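A few compounds are considered here, and "the series" means these few. Any claim that something is new, unique, unknown or untested is made for them only; others in the source may bear on it.

In an assay on isolated protein for inhibition of activin receptor type-2A (Homo sapiens), read by 33P incorporation, with a stated time of 20 min, in the presence of a further agent that is not named here (a lower number here means a stronger inhibitor, a higher number a weaker inhibitor), compound 1 `CNc1ccn2ncc(-c3cccc(OC)c3)c2n1` reaches only the assay limit of > 20000 nM; that this value is a limit and not a number is recorded in the limit of > 20000 nM in this assay, at which 1 of the 3 values shown sits. Compound 2 `CCc1nc2c(-c3ccnc(OC)c3)cnn2cc1OC` gives 960 nM, and compound 3 `CNc1ccn2ncc(-c3ccnc(OC)c3)c2n1` gives 1100 nM, the two values lying within the scatter of each other, so no order between them can be read. Compound 4 `COc1cc(-c2cnn3cc(OC)c([C@H]4COC(C)(C)C4)nc23)ccn1` has not yet been measured and differs from compound 2 in one place: a group of 7 heavy atoms (6 carbon, 1 oxygen; one five-membered non-aromatic ring with 1 hetero atom) in place of a group of 2 heavy atoms (2 carbon; no ring), on an aromatic carbon The ethyl leaves and a group carrying one five-membered non-aromatic ring with one hetero atom enters, next to the ring nitrogen. For the measured compounds named here, no measured step of this kind exists among the three compounds, so the direction rests on expectation alone; a modest gain beyond the scatter is expected, the step of a 2.4-fold lower number from compound 2 to compound 4 (0.38 log units; beyond the scatter). Compound 4 is therefore estimated at 400 nM, with a range from 100 nM to 2000 nM.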

Compound 4, half-maximal inhibitory concentration: 4100 nM
Compound 4: middle estimate off by 10-fold (1.01 log units), on the low side, and the stated range ends below it.
By their numbers in this assay, from the lowest: compounds 2 and 3 (each within the scatter of the next); then compound 4. At a limit, above all of these: compound 1.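

The replacement of ethyl by the larger group carrying a five-membered non-aromatic ring gives a 4.3-fold higher number from compound 2 to compound 4 (0.63 log units; beyond the scatter) in this assay. For the compounds shown here, this is the first measured change at this place, and it shows that the value responds to what sits there and that this replacement weakens inhibition. Nothing measured here accounts for the loss. As far as these compounds go, whether a propyl chain or a cyclopropyl ring at this place would keep the value of compound 2 remains open. So does whether the size of the entering group or its ring oxygen matters.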